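The compounds below may be only part of what the source reports. "The series", "measured", "known", "first", "only" and "open" are said of these compounds alone.

Measured compounds:
compound 1, `COC(=O)c1c(Nc2ccccc2)sc(C(=O)c2ccc(OC)cc2)c1C`, 18%
compound 2, `COC(=O)c1c(Nc2ccc(C)cc2)sc(C(=O)c2ccc(OC)cc2)c1C`, "not active" (no number reported)
compound 3, `COC(=O)c1c(Nc2ccccc2)sc(C(=O)c2ccc(C)cc2)c1C`, 3.16%

In a functional assay, with a stated time of 150 min, tested at 10 ug/mL (a higher number here means a stronger effect of the compound at the concentration tested, a lower number a weaker effect), compound 3 gives 3.16%, the lowest of the two numbers reported; its nearest neighbour is compound 1, which gives 18%. Compound 2 is reported as "not active" (no number reported) with no number. Among the measured compounds shown here, the one measured step with a number, a number 14.8 percentage points lower from compound 1 to compound 3 (beyond the scatter), concerns a different place than the change at hand and so does not bear on it directly. Compound 4, `COC(=O)c1c(Nc2ccc(C)cc2)sc(C(=O)c2ccc(C)cc2)c1C`, differs from compound 3 in one way: methyl in place of hydrogen on an aromatic carbon. The same change, made on compound 1, leads to compound 2, which is inactive where compound 1 shows a modest effect. Starting from the already low compound 3, a step of a number 2.2 percentage points lower from compound 3 to compound 4 (within the scatter) is therefore expected, that is no rise and most likely a small fall, within or near the scatter. Compound 4 is estimated at 1%, in the range from -8% to 10%, and may well be reported as not active.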

Compound 4, a percentage reported as activity, at one concentration (the size of the read-out at that concentration, not a potency): "not active" (no number reported)
No number was reported for compound 4; there is nothing to compare the estimate with.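

Compound 4, like compound 2, is reported without a number in this assay, so no new step can be read from compound 3 to compound 4. No measured evidence explains this result. The compounds shown leave open how large any effect of the added methyl on compound 3 really is.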